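A few compounds are considered here, and "the series" means these few. Any claim that something is new, unique, unknown or untested is made for them only; others in the source may bear on it.

Compound 1 `CN1CC(=O)N(C)c2cnc(Nc3ccc(S(N)(=O)=O)cc3)nc21` gives 495 nM in an assay on Sf9 cells for inhibition of serine/threonine-protein kinase 4 (Homo sapiens), read by luminescence and ADP-Glo, with a stated time of 1 h, in the presence of a further agent that is not named here; on this read-out higher numbers stand for weaker inhibition and lower numbers for stronger inhibition.
Compound 2 `CC(C)CC1C(=O)N(C)c2cnc(Nc3ccc(S(N)(=O)=O)cc3)nc2N1C` gives 77 nM in this assay.
Compound 3 `CNS(=O)(=O)c1ccc(Nc2ncc3c(n2)N(C)C(c2c(F)cccc2F)C(=O)N3C)cc1` gives 318 nM in this assay.

Among these three numbers, compound 3 stands second highest. Its nearest neighbour is compound 1, whose number lies within the usual scatter of that of compound 3, so the two cannot be told apart. Compound 2 lies furthest away, with a clearly lower number, which in this assay means stronger inhibition.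

Compound 4 `CN1C(=O)C(c2c(F)cccc2F)N(C)c2nc(Nc3ccc(S(=O)(=O)NCC4CC4)cc3)ncc21` differs from compound 3 in one place: cyclopropyl in place of hydrogen on a saturated chain carbon bound to a sulfonamide nitrogen. Among the measured compounds shown here, only one measured step is available, a 6.4-fold lower number from compound 1 to compound 2 (0.81 log units; beyond the scatter), and it concerns a different place, a saturated ring carbon within the shared core, so it bears only loosely on a change on the chain carbon bound to the sulfonamide nitrogen. For the measured compounds named here, no measured pair shows what growing the group on that nitrogen does. A change there is therefore expected to make little difference, though a modest shift in either direction cannot be ruled out. The step from compound 3 to compound 4 is expected to be a 1.3-fold lower number from compound 3 to compound 4 (0.10 log units; within the scatter), within the scatter. Compound 4 is accordingly estimated at 250 nM, with a likely range from 90 nM to 700 nM.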

Compound 4, half-maximal inhibitory concentration: 79 nM
Compound 4: the middle estimate sits 3.2-fold (0.50 log units) above what was measured; the measured number lies below the stated range.
By their numbers in this assay, from the lowest: compounds 2 and 4 (each within the scatter of the next); then compounds 3 and 1 (each within the scatter of the next).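

In this assay, the group on the sulfonamide nitrogen proves to be a place that matters: replacing methylsulfamoyl with (cyclopropylmethyl)sulfamoyl gives a 4.0-fold lower number from compound 3 to compound 4 (0.60 log units; beyond the scatter), and the lower number means stronger inhibition. Among the compounds shown here, this is the first measured step at this place, since the earlier step concerned a saturated ring carbon within the shared core, and it shows that the group on this nitrogen can be enlarged without losing inhibition, at least in the setting of compound 3. Nothing available here explains why the cyclopropylmethyl group gives this gain, so it stands as an observation only.

Because this is a single pair, it cannot separate the effect of the three-membered ring from that of simply extending the group on the nitrogen, and a straight propyl or butyl chain would be the natural comparison. It also leaves open whether an amine or a carboxylic acid at the end of such a chain would be tolerated, and whether the same change would give a similar step on other members of the series, such as compound 2.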